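A methylsulfanyl group on the phenyl ring of compound 1

The compounds below may be only part of what the source reports. "The series", "measured", "known", "first", "only" and "open" are said of these compounds alone.

Compound 1 `CCC1=C(O)c2c(oc(-c3ccccc3)cc2=O)C(CC)(CC)C1=O` was tested in a functional assay on KB cells (Homo sapiens) for antiproliferative activity, read by sulforhodamine B assay, with a stated time of 3 days; a lower number here means that less compound is needed, a higher number that more compound is needed for the effect. In this assay compound 1 reaches only a limit, > 236 uM, so no number is known for it. Two relatives carry a group on the same aromatic ring. Compound 2 `CCCc1ccc(-c2cc(=O)c3c(o2)C(CC)(CC)C(=O)C(CC)=C3O)cc1` also stops at a limit, > 53 uM. Compound 3 `CCOc1ccc(-c2cc(=O)c3c(o2)C(CC)(CC)C(=O)C(CC)=C3O)cc1` likewise gives only a limit, > 52.4 uM. With every value a limit, the steps a step that the two limits leave unreadable from compound 1 to compound 2, a step that the two limits leave unreadable from compound 1 to compound 3 and a step that the two limits leave unreadable from compound 2 to compound 3 have no readable size.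

Compound 4 `CCC1=C(O)c2c(oc(-c3ccc(SC)cc3)cc2=O)C(CC)(CC)C1=O` arises from compound 1 by methylsulfanyl in place of hydrogen on an aromatic carbon. Among the measured compounds shown here, no measured step tells how this change acts, and the two neighbouring changes left their compounds at limits. Compound 4 is therefore expected to stay weak, with the step of an at least 1.5-fold lower number from compound 1 to compound 4 (0.19 log units; that floor lies within the scatter) expected to be small. The estimate for compound 4 is 150 uM, ranging from 40 uM to 300 uM.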

Compound 4, concentration for half-maximal effect: > 52.1 uM
Compound 4: only a limit was reported; the forecaster's own chance of this, stated with the estimate: 70%; the middle value does not contradict the limit.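

Among the compounds shown here, compound 4 also stops at a limit, so no step from compound 1, compound 2 or compound 3 to compound 4 can be read. The compounds shown leave open whether any of these phenyl-ring groups changes the activity at all.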